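This account rests on a few compounds, and the source may have more. Where it says the series, first, only, none or still open, it means among the compounds named here.

Measured so far:
- compound 1 `Oc1cccc(-c2cc(-c3ccc(Cl)cc3)nc(-c3ccsc3)c2)c1`: 11.7%
- compound 2 `Oc1cccc(-c2cc(-c3ccc(Cl)cc3)nc(-c3ccco3)c2)c1`: 27.1%

For the measured compounds named here, in an assay on isolated protein for inhibition of DNA topoisomerase 1 (Homo sapiens), with a stated time of 30 min, tested at 100 uM (a lower number here means a weaker effect, a higher number a stronger effect of the compound at the concentration tested), compound 2 gives the higher of the two numbers; the only step measured, a number 15.4 percentage points higher from compound 1 to compound 2 (beyond the scatter), separates it from compound 1. Compound 3 `Oc1cccc(-c2cc(-c3ccncc3)nc(-c3ccc(Cl)cc3)c2)c1` differs from compound 2 in one place: pyridin-4-yl in place of furan-2-yl on an aromatic carbon. Going by the values given here, the single step on record swaps one five-membered ring for another at this position and was modest, so it shows that the ring attached here can move the reading, but no measured pair tells how a six-membered ring with one nitrogen behaves there. The expected step of a number 7.1 percentage points lower from compound 2 to compound 3 (within the scatter) is therefore small and of uncertain direction, with the wide range reflecting that gap. For compound 3 the estimate in this assay is 20%, between 5% and 40%.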

Compound 3, a percentage reported as inhibition, at one concentration (the size of the read-out at that concentration, not a potency): 8%
Estimate against measurement, compound 3: 12 percentage points above; the measured number falls inside the stated range.
By their numbers in this assay, from the lowest: compounds 3 and 1 (each within the scatter of the next); then compound 2.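

In this assay, the position next to the ring nitrogen now carries a six-membered ring as well as two five-membered ones, and pyridin-4-yl does not keep the reading of furan-2-yl (a number 19.1 percentage points lower from compound 2 to compound 3 (beyond the scatter)). Set against thiophen-3-yl, the same group gives no difference that stands out from the scatter (a number 3.7 percentage points lower from compound 1 to compound 3 (within the scatter)), so among these three groups furan-2-yl alone stands apart, and ring size does not sort the readings. Nothing available accounts for why furan-2-yl differs from the other two groups.

Going by these compounds, how thiophen-2-yl, or a group without a ring such as an amine, would read at this position stays open. So does the contribution of the 3-hydroxyphenyl and 4-chlorophenyl groups, which are the same in all three compounds.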